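The compounds below may be only part of what the source reports. "The series", "measured", "known", "first", "only" and "open" are said of these compounds alone.

Compound 1 `O=C(Nc1ccc(Oc2ccnc3[nH]ccc23)cc1)c1cc2cccnc2n(-c2ccccc2)c1=O` gives 360 nM in a functional assay on A549 cells (Homo sapiens) for antiproliferative activity, read by MTT assay, with a stated time of 72 h; a higher number here means a weaker inhibitor, a lower number a stronger inhibitor. Compound 2 `O=C(Nc1ccc(Oc2ccnc3[nH]ccc23)cc1)c1cc2cccnc2n(-c2ccc(F)cc2)c1=O` carries fluoro in place of hydrogen on an aromatic carbon, gives 210 nM in this assay, and the step of a 1.7-fold lower number from compound 1 to compound 2 (0.23 log units; within the scatter). Compound 3 `Cn1ccc2c(Oc3ccc(NC(=O)c4cc5cccnc5n(-c5ccccc5)c4=O)cc3)ccnc21` differs from compound 1 by methyl in place of hydrogen on an aromatic nitrogen; compound 3 gives 850 nM, so that a 2.4-fold higher number from compound 1 to compound 3 (0.37 log units; beyond the scatter). Compound 4 `Cn1ccc2c(Oc3ccc(NC(=O)c4cc5cccnc5n(-c5ccccc5)c4=O)cc3F)ccnc21` has not been measured; it differs from compound 3 by fluoro in place of hydrogen on an aromatic carbon. Among the measured compounds shown here, this is the same kind of change as the one from compound 1 to compound 2, though not the same: there the fluoro stands para to a large group, here ortho to a large group and meta to a large group. The step is expected to be a 1.2-fold lower number from compound 3 to compound 4 (0.08 log units; within the scatter), because a 1.7-fold lower number from compound 1 to compound 2 (0.23 log units; within the scatter) was within the scatter. Compound 4 is therefore estimated at 700 nM, between 300 nM and 1700 nM.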

Compound 4, half-maximal inhibitory concentration: 430 nM
For compound 4 the middle estimate is 1.6-fold (0.21 log units) above the measured one, and the stated range covers the measured number.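

In this assay fluoro in place of hydrogen on an aromatic carbon brings a 2.0-fold lower number from compound 3 to compound 4 (0.30 log units; within the scatter) and so stays within the scatter, as the earlier step does. The two steps do not differ: the same change on two cores in this assay, a 1.7-fold lower number (0.23 log units; within the scatter) from compound 1 to compound 2 and a 2.0-fold lower number (0.30 log units; within the scatter) from compound 3 to compound 4, 1.2-fold (0.06 log units) apart, within the scatter of two such steps

The change therefore carries from the core of compound 1 to the core of compound 3 with no difference that these numbers can detect. This does not establish a real effect of fluoro on either core, since neither step lies beyond the scatter, the fluoro stands at a different place in each pair, and two pairs set no general rule.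

The compounds shown leave open whether chloro, methoxy or an amine in place of that hydrogen would give a step beyond the scatter. They also leave open what fluoro would do on each core at the place it holds on the other.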